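From 4-chlorophenyl to 2-bromophenyl on a shared core

A few compounds are considered here, and "the series" means these few. Any claim that something is new, unique, unknown or untested is made for them only; others in the source may bear on it.

- compound 1 `COc1ccc(Cn2ccc3nc(-c4ccccc4)nc-3c2)cc1`: > 100000 nM
- compound 2 `Fc1ccc(Cn2ccc3nc(-c4ccccc4)nc-3c2)cc1`: > 100000 nM
- compound 3 `Clc1ccc(Cn2ccc3nc(-c4ccccc4)nc-3c2)cc1`: > 100000 nM

In an ADME assay on MDBK cells (Bos taurus) for cytotoxicity (a lower number here means that less compound is tolerated, a higher number that more compound is tolerated), compound 3 gives > 100000 nM, which is a limit and not a number. The other two compounds read the same way: the limit of > 100000 nM in this assay, at which 3 of the 3 values shown sit.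

Compound 4 `Brc1ccccc1Cn1ccc2nc(-c3ccccc3)nc-2c1` has 2-bromophenyl in place of 4-chlorophenyl on a saturated chain carbon bound to an aromatic nitrogen.

Within the data shown here, three measured steps bear on this: a step that the two limits leave unreadable from compound 1 to compound 2, a step that the two limits leave unreadable from compound 1 to compound 3 and a step that the two limits leave unreadable from compound 2 to compound 3. None has a readable size and none brings in 2-bromophenyl, so no firm direction can be expected, and only a step within the scatter is anticipated.

The expected step is a number no higher from compound 3 to compound 4 (the limit leaves the size open).

For compound 4 the estimated value is 100000 nM, with an expected range from 40000 nM to 200000 nM.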

Compound 4, half-maximal cytotoxic concentration: > 100000 nM
Compound 4: only a limit was reported (the forecaster's own chance of this, stated with the estimate: 75%); the middle value sits exactly at the limit.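

No step from compound 1, compound 2 or compound 3 to compound 4 can be read in this assay, where each result is a limit and not a number: the limit of > 100000 nM in this assay, at which 4 of the 4 values shown sit.

The compounds shown leave open how these four differ in this assay, if they differ at all.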